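Replacing a nitrile with a carbamoylpyridinyl group

The source may report more compounds than this note shows. Statements on the series, on what has been measured and on what is new or still open speak of the compounds shown alone.

For the measured compounds named here, compound 3 `N#Cc1cnc(C(O)CCCCCCc2ccccc2)o1` gives 4200 nM in an assay (Rattus norvegicus) for inhibition of Fatty-acid amide hydrolase 1 (Homo sapiens) (on this read-out higher numbers stand for weaker inhibition and lower numbers for stronger inhibition), the highest of the three numbers measured so far. Compound 1 `N#Cc1cccc(-c2cnc(C(=O)CCCCCCc3ccccc3)o2)c1` gives 15 nM, and compound 2 `CSc1cnc(C(=O)CCCCCCc2ccccc2)o1` gives 25 nM; both sit far lower than compound 3. Compound 4 `NC(=O)c1ccc(-c2cnc(C(O)CCCCCCc3ccccc3)o2)nc1` differs from compound 3 in one place: 5-carbamoylpyridin-2-yl in place of cyano on an aromatic carbon. Going by the values given here, the only measured step at the same spot on the shared core is a 1.7-fold higher number from compound 1 to compound 2 (0.22 log units; within the scatter), where a large group was exchanged for a small one with little effect. That step bears on the present change only loosely, since compound 3 and compound 4 carry the alcohol rather than the carbonyl of compound 1 and compound 2. The step expected here is small, a 1.4-fold lower number from compound 3 to compound 4 (0.15 log units; within the scatter), and may well stay within the usual scatter. Compound 4 is estimated at 3000 nM, in a range of 700 nM to 15000 nM.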

Compound 4, inhibition constant: 3000 nM
Compound 4: the middle estimate sits on the measured number at the digits printed; the measured number falls inside the stated range.
By their numbers in this assay, from the lowest: compounds 1 and 2 (each within the scatter of the next); then compounds 4 and 3 (each within the scatter of the next).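

Exchanging cyano for the much larger 5-carbamoylpyridin-2-yl gives a 1.4-fold lower number from compound 3 to compound 4 (0.15 log units; within the scatter) in this assay, so a new ring and an amide at this position leave the number within the scatter. The earlier step, a 1.7-fold higher number from compound 1 to compound 2 (0.22 log units; within the scatter), came from compounds carrying the carbonyl, and this one shows the same small response with the alcohol in its place. No other measurement here bears on why the number stays put. Still open, from the compounds shown here alone, is whether an amine or a carboxylic acid at this position would move the number, and what 5-carbamoylpyridin-2-yl does when the alcohol is a carbonyl.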